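A Ring Swap at the Urea Nitrogen of Compound 1

A few compounds are considered here, and "the series" means these few. Any claim that something is new, unique, unknown or untested is made for them only; others in the source may bear on it.

Of the compounds shown here, three sharing a common core have been tested in a functional assay on Shh Light II cells (Mus musculus) for inhibition, read by a luciferase reporter; on this read-out higher numbers stand for weaker inhibition and lower numbers for stronger inhibition. Compound 1 `O=C(NCC1CCC1)N1CCC(c2nc(-c3ccc4ccccc4n3)no2)CC1` gives 410 nM in this assay. Compound 2 `Cn1c(-c2noc(N3CCN(C(=O)NC4CCCCC4)CC3)n2)nc2ccccc21` gives 5 nM, and compound 3 `C[C@H]1C[C@H](c2nc(-c3ccc4ccccc4n3)no2)CCN1C(=O)Nc1ccccc1Cl` gives 900 nM. Among these three numbers compound 1 holds the second highest; compound 3 stands above it by a margin beyond the usual scatter, while compound 2 lies far below it, also well beyond the scatter.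

Compound 4 `O=C(NC1CCOCC1)N1CCC(c2nc(-c3ccc4ccccc4n3)no2)CC1` is a close relative of compound 1 that has not yet been measured. The difference is a single exchange on the urea: oxan-4-yl in place of cyclobutylmethyl on an amide-type nitrogen. For the measured compounds named here, no measured pair in this set shows what such a swap does, so the expectation rests on the small size of the change alone. A modest shift in either direction, or none beyond the scatter, is the reasonable expectation, with the step from compound 1 to compound 4 estimated as a 1.0-fold lower number from compound 1 to compound 4 (0.01 log units; within the scatter). Compound 4 is therefore expected to give about 400 nM in this assay, with a plausible range from 150 nM to 1200 nM.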

Compound 4, half-maximal inhibitory concentration: 480 nM
For compound 4 the middle estimate is 1.2-fold (0.08 log units) below the measured one; low and high end bracket the measured number.
By their numbers in this assay, from the lowest: compound 2; then compounds 1, 4 and 3 (each within the scatter of the next, the first and the last beyond it).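

For the compounds shown here, at the amide-type nitrogen of the urea, compound 1 and compound 4 form the first pair here that differs in one place, and this assay gives a 1.2-fold higher number from compound 1 to compound 4 (0.07 log units; within the scatter) for that swap. Cyclobutylmethyl, with its four-membered carbon ring, can therefore be exchanged for oxan-4-yl, with its six-membered ring and one hydrogen-bond acceptor, without a shift beyond the scatter. Nothing available explains why the number holds across this exchange.

From the compounds shown here alone, whether the position accepts very different groups stays open, such as an amine like piperidin-4-yl, a carboxylic acid or a longer chain like n-hexyl. Compound 2 and compound 3 differ from compound 1 in more than one place, so they cannot settle this question.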